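The source may report more compounds than this note shows. Statements on the series, on what has been measured and on what is new or still open speak of the compounds shown alone.

In an ADME assay on cells (Fibroblast, Gallus gallus) for cytotoxicity, read by CCK-8 assay, with a stated time of 48 h (on this read-out higher numbers stand for lower toxicity in this test and lower numbers for higher toxicity in this test), compound 1 `CCC(CC)O[C@@H]1C=C(C(=O)O)C[C@H](NCc2ccc(C(C)(C)C)cc2)[C@H]1NC(C)=O` gives > 200000 nM, a limit of the assay. Compound 2 `CCC(CC)O[C@@H]1C=C(C(=O)O)C[C@H](NCc2ccc(OC(C)C)cc2)[C@H]1NC(C)=O` gives > 200000 nM, also a limit. Compound 3 `CCC(CC)Oc1ccc(CN[C@H]2CC(C(=O)O)=C[C@@H](OC(CC)CC)[C@@H]2NC(C)=O)cc1` gives > 200000 nM, again a limit, and so it shares the limit of > 200000 nM in this assay, at which 3 of the 3 values shown sit, with the other two. Compound 4 `CCC(CC)O[C@@H]1C=C(C(=O)O)C[C@H](NCc2ccc(Oc3ccccc3)cc2)[C@H]1NC(C)=O` differs from compound 3 by phenyl in place of pentan-3-yl on an oxygen on an aromatic ring, with phenyl in place of pentan-3-yl on an oxygen on an aromatic ring. The closest measured change at that oxygen is a step that the two limits leave unreadable from compound 2 to compound 3, while a step that the two limits leave unreadable from compound 1 to compound 2 and a step that the two limits leave unreadable from compound 1 to compound 3 add no readable size either. On the strength of these steps, no change beyond the scatter is expected in this assay, and no direction can be given. The expected step is a number no higher from compound 3 to compound 4 (the limit leaves the size open). For compound 4 the estimate is 200000 nM, with an expected range from 80000 nM to 400000 nM.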

Compound 4, half-maximal cytotoxic concentration: > 200000 nM
Compound 4: a limit, no number (the forecaster's own chance of this, stated with the estimate: 80%); the middle value lies on the limit itself.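

Compound 4 stands at the same limit as compound 1, compound 2 and compound 3, so no step among these compounds can be read: the limit of > 200000 nM in this assay, at which 4 of the 4 values shown sit. The compounds shown leave open whether the four differ from one another at all, and by how much.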